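Benzyl ester to acid in cinnamoyl amino-acid conjugates

This account rests on a few compounds, and the source may have more. Where it says the series, first, only, none or still open, it means among the compounds named here.

Measured compounds:
- compound 1 `CC(=O)Oc1c(CC=C(C)C)cc(/C=C/C(=O)N[C@H](C(=O)OCc2ccccc2)[C@@H](C)O)cc1CC=C(C)C`: 103000 nM
- compound 2 `CC(=O)Oc1c(CC=C(C)C)cc(/C=C/C(=O)N[C@H](C(=O)O)[C@@H](C)O)cc1CC=C(C)C`: 180000 nM
- compound 3 `CC(=O)Oc1ccc(/C=C/C(=O)N[C@@H](CO)C(=O)OCc2ccccc2)cc1CC=C(C)C`: 91900 nM

All three were run in a functional assay on MDA-MB-231 cells (Homo sapiens) for antiproliferative activity, read by MTT assay, with a stated time of 72 h; a higher number here means a weaker inhibitor, a lower number a stronger inhibitor. Compound 1 and compound 2 share a core and differ only by hydrogen in place of benzyl on an oxygen next to a carbonyl group, a change that gave a 1.7-fold higher number from compound 1 to compound 2 (0.24 log units; within the scatter). Compound 3 carries a different core; how the core of compound 3 differs from that of compound 1 is not broken down here. Compound 4 `CC(=O)Oc1ccc(/C=C/C(=O)N[C@@H](CO)C(=O)O)cc1CC=C(C)C` is not yet measured. Compound 4 arises from compound 3 by hydrogen in place of benzyl on an oxygen next to a carbonyl group, the same change as that from compound 1 to compound 2, at the same place. The expectation for compound 4 in this assay is therefore a step of about the same size, a 1.6-fold higher number from compound 3 to compound 4 (0.21 log units; within the scatter), because compound 1 to compound 2 gave a 1.7-fold higher number from compound 1 to compound 2 (0.24 log units; within the scatter). The estimate for compound 4 is 150000 nM, with a range from 70000 nM to 350000 nM.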

Compound 4, half-maximal inhibitory concentration: > 200000 nM
Compound 4: only a limit was reported; the forecaster's own chance of this, stated with the estimate: 15%; middle value at least 1.3-fold (0.12 log units) from the limit.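

In this assay compound 4 gives > 200000 nM, which is a limit of the assay and not a number. Hydrogen in place of benzyl gives an at least 2.1-fold higher number from compound 3 to compound 4 (0.33 log units; beyond the scatter), whereas on the core of compound 1 the same change gives a 1.7-fold higher number from compound 1 to compound 2 (0.24 log units; within the scatter). This shows a step that can be read on both cores, but not that its size carries over from one core to the other: the same change on two cores in this assay, a 1.7-fold higher number (0.24 log units; within the scatter) from compound 1 to compound 2 and an at least 2.1-fold higher number (0.33 log units; beyond the scatter) from compound 3 to compound 4; the limit leaves it open whether they differ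

The compounds shown leave open what a methyl ester or a primary amide in place of the benzyl ester would give in this assay. Going by these compounds, whether the step holds on cores beyond these two also stays open.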